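A few compounds are considered here, and "the series" means these few. Any claim that something is new, unique, unknown or untested is made for them only; others in the source may bear on it.

In a functional assay on A549 cells (Homo sapiens) for antiproliferative activity, read by MTT assay, with a stated time of 48 h (a higher number here means a weaker inhibitor, a lower number a stronger inhibitor), compound 1 (`C=C(c1cc(OC)c(OC)c(OC)c1)c1ccc(OC)c(O)c1NC(C)=O`) gives 80 nM and compound 2 (`C=C(c1cc(OC)c(OC)c(OC)c1)c1ccc(OC)c(O)c1NC(=O)COCC`) gives 880 nM as the higher of the two numbers. Among the measured compounds shown here, the one measured step bearing on the next change is an 11-fold higher number from compound 1 to compound 2 (1.04 log units; beyond the scatter) with ethoxy in place of hydrogen on a saturated chain carbon bound to a carbonyl carbon. That step is large and beyond the scatter. Compound 3 (`C=C(c1cc(OC)c(OC)c(OC)c1)c1ccc(OC)c(O)c1NC(=O)CN(C)C`) carries dimethylamino in place of ethoxy at that same place (dimethylamino in place of ethoxy on a saturated chain carbon bound to a carbonyl carbon). For the measured compounds named here, no measured step covers this swap itself. The entering group matches the leaving one in the counts, so the expectation stays anchored on compound 2 at 880 nM and does not return to compound 1 at 80 nM in full. The expected step is a 1.8-fold lower number from compound 2 to compound 3 (0.25 log units; within the scatter) as a small move toward a lower number. Compound 3 is estimated at 500 nM with 120 nM to 1800 nM as the expected range.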

Compound 3, half-maximal inhibitory concentration: 50 nM
Estimate against measurement, compound 3: 10-fold (1.00 log units) above; the measured number lies below the stated range.
By their numbers in this assay, from the lowest: compounds 3 and 1 (each within the scatter of the next); then compound 2.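

In this assay, the swap at this saturated chain carbon bound to a carbonyl carbon gives an 18-fold lower number from compound 2 to compound 3 (1.25 log units; beyond the scatter), although ethoxy and dimethylamino match in heavy atoms, hydrogen-bond donors and hydrogen-bond acceptors, so those counts do not separate the two groups here. Replacing hydrogen at this place is therefore not penalised for every group: dimethylamino gives a 1.6-fold lower number from compound 1 to compound 3 (0.20 log units; within the scatter), which leaves compound 1 and compound 3 within the scatter of each other, whereas ethoxy gives an 11-fold higher number from compound 1 to compound 2 (1.04 log units; beyond the scatter). No measurement shown accounts for the difference between ethoxy and dimethylamino.

On these data alone, it remains open whether this tolerance extends to amines generally or is particular to dimethylamino. A primary amine, a carboxylic acid or a longer chain carrying the dimethylamino group would each test that question at this place.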